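Trichlorophenyl Analogue in a Series Without Measurable Activity

The source may hold more compounds than are shown below. What is called first, only, known or untested is meant among the compounds shown, and "the series" means these compounds.

Compound 3 `N#CC1=C(N)Oc2c(N)cc3nc4ccccc4nc3c2C12C(=O)N(Cc1cnnn1-c1ccc(Cl)cc1[N+](=O)[O-])c1ccccc12` is one of three spiro compounds that share a core and differ only in the aryl group carried on an aromatic nitrogen. In a functional assay on HepG2 cells (Homo sapiens) for antiproliferative activity, read by MTT assay, with a stated time of 48 h (on this read-out lower numbers stand for stronger inhibition and higher numbers for weaker inhibition), compound 3 gives only a limit, > 50000 nM. Compound 1 `Cc1ccc(C)c(-n2nncc2CN2C(=O)C3(C(C#N)=C(N)Oc4c(N)cc5nc6ccccc6nc5c43)c3ccccc32)c1` likewise yields only the limit of > 50000 nM in this assay. Compound 2 `N#CC1=C(N)Oc2c(N)cc3nc4ccccc4nc3c2C12C(=O)N(Cc1cnnn1-c1c(F)cccc1F)c1ccccc12` also returns only the limit of > 50000 nM in this assay. All three values therefore sit at the limit of > 50000 nM in this assay, at which 3 of the 3 values shown sit, so the steps a step that the two limits leave unreadable from compound 1 to compound 2, a step that the two limits leave unreadable from compound 1 to compound 3 and a step that the two limits leave unreadable from compound 2 to compound 3 cannot be read in size or direction. Compound 4 `N#CC1=C(N)Oc2c(N)cc3nc4ccccc4nc3c2C12C(=O)N(Cc1cnnn1-c1c(Cl)cc(Cl)cc1Cl)c1ccccc12` differs from compound 3 by 2,4,6-trichlorophenyl in place of 4-chloro-2-nitrophenyl on an aromatic nitrogen. Within the data shown here, none of the measured aryl exchanges produced a readable number, so there is no basis for expecting compound 4 to behave differently from its three relatives. Compound 4 is therefore expected to remain unmeasurable in this assay, with an estimated value of 80000 nM (range 30000 nM to 300000 nM). The step that the limit leaves unreadable from compound 3 to compound 4 that this estimate implies is expected to be nil beyond the scatter.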

Compound 4, half-maximal inhibitory concentration: 37800 nM
For compound 4 the middle estimate is 2.1-fold (0.33 log units) above the measured one, within the range that was stated.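

Among the compounds shown, only compound 4, with 2,4,6-trichlorophenyl on the aromatic nitrogen, gives a number rather than a limit in this assay on this core, so an aryl exchange at this position can bring the read-out into the measurable range, while the other compounds stay at a limit: the limit of > 50000 nM in this assay, at which 3 of the 4 values shown sit. The exchange gives an at least 1.3-fold lower number from compound 3 to compound 4 (0.12 log units; that floor lies within the scatter) and an at least 1.3-fold lower number from compound 2 to compound 4 (0.12 log units; that floor lies within the scatter) and an at least 1.3-fold lower number from compound 1 to compound 4 (0.12 log units; that floor lies within the scatter) so no step is shown to go beyond the scatter. The steps among compound 1, compound 2 and compound 3 still cannot be read.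

Going by these compounds, it remains open whether the three chlorines are all needed, as a 2,4-dichlorophenyl or 4-chlorophenyl group could show. On these data alone, it is equally open how an unsubstituted phenyl ring, or an aryl ring bearing an amine or a carboxylic acid, would read at this position.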